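Removing the Methoxy Group: What the Numbers Suggest

This account rests on a few compounds, and the source may have more. Where it says the series, first, only, none or still open, it means among the compounds named here.

Three compounds have been measured in an assay on liver for inhibition of arginase-1 (Bos taurus), with a stated time of 60 min; a higher number here means a weaker inhibitor, a lower number a stronger inhibitor:

Compound 1 `COc1cccc(NCc2ccc(O)c(O)c2)c1`: 185000 nM
Compound 2 `Oc1cccc(NCc2ccc(O)c(O)c2)c1`: 83000 nM
Compound 3 `COc1ccc(NCc2ccc(O)c(O)c2)cc1`: 154000 nM

Compound 3 stands second highest of these three numbers; compound 1 sits close to it and compound 2 somewhat lower, both within the usual scatter, so no order among the three can be claimed. Compound 4 `Oc1ccc(CNc2ccccc2)cc1O` differs from compound 3 by hydrogen in place of methoxy on an aromatic carbon. Within the data shown here, only one measured step touches a methoxy group: a 2.2-fold lower number from compound 1 to compound 2 (0.35 log units; beyond the scatter), where the methyl alone was swapped for hydrogen rather than the whole methoxy group removed, so it bears only loosely on this change. Compounds 1 and 3, which carry the methoxy group in different places, give numbers within the scatter of each other. For compound 4 a step of a 1.0-fold lower number from compound 3 to compound 4 (0.01 log units; within the scatter) is therefore expected in this assay, meaning nothing beyond the scatter. Compound 4 is estimated at 150000 nM, with a range from 60000 nM to 400000 nM.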

Compound 4, half-maximal inhibitory concentration: 164000 nM
Compound 4: the middle estimate sits 1.1-fold (0.04 log units) below what was measured; the measured number falls inside the stated range.
By their numbers in this assay, from the lowest: compounds 2, 3, 4 and 1 (each within the scatter of the next, the first and the last beyond it).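

In this assay, replacing methoxy with hydrogen on the aromatic carbon para to a large group leaves the number within the usual scatter (a 1.1-fold higher number from compound 3 to compound 4 (0.03 log units; within the scatter)). Replacing the methoxy group of compound 1 with hydrogen (a 1.1-fold lower number from compound 1 to compound 4 (0.05 log units; within the scatter)) or the hydroxy group of compound 2 with hydrogen (a 2.0-fold higher number from compound 2 to compound 4 (0.30 log units; within the scatter)) also stays within the scatter, so these compounds show no clear need for any of these groups on this ring. No evidence is available to explain this result. Going by these compounds, whether an amine or a carboxylic acid on this ring would give a number beyond the scatter remains open.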